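The compounds below may be only part of what the source reports. "The series", "measured", "known", "first", "only" and "open" are said of these compounds alone.

Compound 1 `CSCNC(=O)c1ccc(NCc2cncn2Cc2ccc(C#N)cc2)cc1-c1ccccc1`: > 10 uM
Compound 2 `COC(=O)[C@H](CCSC)NC(=O)c1ccc(NCc2cncn2Cc2ccc(Cl)cc2)cc1-c1ccccc1`: > 10 uM

In a functional assay on NIH3T3 cells (Mus musculus) (on this read-out higher numbers stand for an effect only at larger amounts of compound and lower numbers for an effect already at smaller amounts), compound 1 gives only a limit of the assay, > 10 uM. In this assay compound 2 likewise gives only a limit, > 10 uM. Among the compounds with values here, no measured pair differs in a single place, so no measured step exists; what is known is the limit of > 10 uM in this assay, at which 2 of the 2 values shown sit. Compound 3 `N#Cc1ccc(Cn2cncc2CNc2ccc(C(=O)Nc3cccc([N+](=O)[O-])c3)c(-c3ccccc3)c2)cc1` has not yet been measured. It differs from compound 1 by 3-nitrophenyl in place of (methylsulfanyl)methyl on an amide-type nitrogen. Since nothing measured leaves the limit, the step of a number no higher from compound 1 to compound 3 (the limit leaves the size open) is expected to show no direction beyond the scatter. Compound 3 is estimated at 10 uM, between 3 uM and 30 uM.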

Compound 3, concentration for half-maximal effect: > 10 uM
Compound 3: no number, only a limit; the forecaster's own chance of this, stated with the estimate: 60%; the middle value sits exactly at the limit.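

In this assay compound 3 gives only a limit, > 10 uM. Within the data shown here, compound 1 also gives only a limit, so no step between compound 1 and compound 3 can be read. The compounds shown leave open whether the group on the amide-type nitrogen affects this read-out at all: the limit of > 10 uM in this assay, at which 3 of the 3 values shown sit.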